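Replacing 2-methoxyphenyl with 4-chlorophenyl in compound 3

The compounds below may be only part of what the source reports. "The series", "measured", "known", "first", "only" and "open" are said of these compounds alone.

In a functional assay on HeLa cells (Homo sapiens) for inhibition, read by MTT assay, with a stated time of 72 h (a lower number here means a stronger inhibitor, a higher number a weaker inhibitor), compound 1 `COc1cc(OC)c(OC)cc1/C=C/C(=O)c1c(OC)cc(O)c(CC=C(C)C)c1O` gives > 50000 nM and this value is a limit, not a number. Compound 2 `COc1cc(O)cc(O)c1C(=O)/C=C/c1ccc([N+](=O)[O-])cc1` gives > 50000 nM and this value is likewise a limit. Within the data shown here, compound 3 `COc1cc(OC)c(C(=O)/C=C/c2ccccc2OC)c(OC)c1` gives 19600 nM as the only true number among the three, so it has no measured neighbour to be ranked against.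

The next compound, compound 4 `COc1cc(OC)c(C(=O)/C=C/c2ccc(Cl)cc2)c(OC)c1`, keeps the rest of compound 3 and carries 4-chlorophenyl in place of 2-methoxyphenyl on a double-bonded chain carbon bound to a double-bonded chain carbon. The change comes to 4-chlorophenyl in place of 2-methoxyphenyl on a double-bonded chain carbon bound to a double-bonded chain carbon and nothing else in the structure differs.

Among the measured compounds shown here, no two measured compounds differ in one place only, so no measured step gives a guide to its size. The expected change a 1.3-fold lower number from compound 3 to compound 4 (0.12 log units; within the scatter) is therefore estimated to stay within the usual scatter of this assay with no direction favoured. The expectation starts from compound 3 at 19600 nM as its only numerical anchor. For the measured compounds named here, a reading that stops at a limit also remains possible for compound 4 given the limit of > 50000 nM in this assay, at which 2 of the 3 values shown sit, so far.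

For compound 4 the estimated value is 15000 nM with an expected range from 4000 nM to 50000 nM awaiting measurement.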

Compound 4, half-maximal inhibitory concentration: 3900 nM
Compound 4: middle estimate off by 3.8-fold (0.59 log units), on the high side; the measured number lies below the stated range.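

In this assay, among these compounds, exchanging 2-methoxyphenyl for 4-chlorophenyl on a double-bonded chain carbon bound to a double-bonded chain carbon gives the first measured step, a 5.0-fold lower number from compound 3 to compound 4 (0.70 log units; beyond the scatter). Among the compounds shown here, with the rest of the structure unchanged, this shows that the group at this place can move the number beyond the scatter, which the earlier compounds could not show, although one step cannot separate the loss of the methoxy group from the arrival of the chlorine. Compound 1 and compound 2 each stop at a limit and differ from compound 4 in more than one place, so they add no step to this reading: the limit of > 50000 nM in this assay, at which 2 of the 4 values shown sit.

As far as these compounds go, what remains open is whether the lower number belongs to the chlorine itself or would also appear with unsubstituted phenyl or 4-bromophenyl in the same place. From the compounds shown here alone, it is equally open how a phenyl ring carrying an amine or a carboxylic acid would read in this assay, and whether the step would keep its size on a different core, such as that of compound 2.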